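Cyano for fluoro on the benzamide of compound 2

This account rests on a few compounds, and the source may have more. Where it says the series, first, only, none or still open, it means among the compounds named here.

Working notes on the series. Of the compounds shown here, two carry numbers so far: compound 1 `CCc1ccc(C(=O)Nc2cccc(NC(=O)COc3ccc4c(=O)ccoc4c3)c2)cc1` and compound 2 `O=C(COc1ccc2c(=O)ccoc2c1)Nc1cccc(NC(=O)c2ccc(F)cc2)c1`. In an assay on isolated protein for inhibition of Rho-associated protein kinase 1 (Homo sapiens), read by scintillation counting, radiometric assay and 33P incorporation, with a stated time of 40 min, in the presence of a further agent that is not named here (a lower number here means a stronger inhibitor, a higher number a weaker inhibitor), compound 1 gives 235 nM, and in the same assay compound 2 gives 129 nM. Within the data shown here, the one step computed so far, a 1.8-fold lower number from compound 1 to compound 2 (0.26 log units; within the scatter), is within the scatter, so the two compounds cannot be ordered. Compound 2 stands at the lowest of the two numbers, but its nearest neighbour, compound 1, is within the scatter of it.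

Compound 3 `N#Cc1ccc(C(=O)Nc2cccc(NC(=O)COc3ccc4c(=O)ccoc4c3)c2)cc1` is not yet measured. Its change from compound 2 is cyano in place of fluoro on an aromatic carbon, in words cyano in place of fluoro on an aromatic carbon. Among the measured compounds shown here, no measured step covers the fluoro-to-cyano exchange; the only step in hand is the ethyl-to-fluoro step at the same position, which was within the scatter. The expectation in this assay is therefore no step beyond the scatter, in either direction, and the step of a 1.2-fold higher number from compound 2 to compound 3 (0.07 log units; within the scatter) is set to reflect that. The estimate for compound 3 in this assay is 150 nM, expected to fall between 60 nM and 400 nM.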

Compound 3, half-maximal inhibitory concentration: 123 nM
The estimate for compound 3 lay 1.2-fold (0.09 log units) above the measured number; low and high end bracket the measured number.
By their numbers in this assay, from the lowest: compounds 3, 2 and 1 (each within the scatter of the next).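

Cyano in place of fluoro gives a 1.0-fold lower number from compound 2 to compound 3 (0.02 log units; within the scatter) in this assay and cyano in place of ethyl gives a 1.9-fold lower number from compound 1 to compound 3 (0.28 log units; within the scatter) in the same assay, so all three groups on this aromatic carbon, para to a large group, now lie within the scatter of one another. Among these compounds, the earlier pair covered only ethyl and fluoro, whereas this result extends the same reading to a group that enters with a triple bond and a hydrogen-bond acceptor: across these three compounds, the change at this position gives no step that can be read as a difference. No measurement available here bears on why these numbers lie so close.

On these data alone, it remains open whether any group at this position can move the number beyond the scatter in this assay, for example an amine, a carboxylic acid or a longer chain. The compounds shown also share the rest of their structure, so they leave open how much the core and its two amide links contribute.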